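A few compounds are considered here, and "the series" means these few. Any claim that something is new, unique, unknown or untested is made for them only; others in the source may bear on it.

Compound 1 `C[C@H](NC(=O)c1[nH]cnc1C(=O)Nc1ccc(Cl)c(Cl)c1)c1ccccc1` gives 5900 nM in a functional assay on HL-60 cells (Homo sapiens), with a stated time of 4 days; on this read-out lower numbers stand for stronger inhibition and higher numbers for weaker inhibition. Compound 2 `COC(=O)[C@@H](C)NC(=O)c1[nH]cnc1C(=O)Nc1ccc(Cl)c(Cl)c1` returns only a limit in this assay, > 62500 nM. The step of an at least 10-fold higher number from compound 1 to compound 2 (1.02 log units; beyond the scatter) is accordingly bounded by the limit of > 62500 nM in this assay, at which 1 of the 2 values shown sits. Compound 3 `C[C@@H](NC(=O)c1[nH]cnc1C(=O)Nc1ccc(Cl)c(Cl)c1)C(=O)OC(C)(C)C` differs from compound 2 by tert-butyl in place of methyl on an oxygen next to a carbonyl group. Within the data shown here, no measured step covers this ester exchange; the single known step concerns the 1-phenylethyl to 1-(methoxycarbonyl)ethyl exchange and says nothing about the ester alkyl. Compound 3 is therefore expected to stay close to the limit, estimated at 50000 nM with a range from 12000 nM to 200000 nM. The expected step of an at least 1.2-fold lower number from compound 2 to compound 3 (0.09 log units; that floor lies within the scatter) is small, within the scatter.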

Compound 3, half-maximal inhibitory concentration: 2500 nM
Beside the measured number, compound 3's estimate is 20-fold (1.30 log units) above it, outside the stated range (below it).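

The ester alkyl on the oxygen next to a carbonyl group strongly affects this series in this assay: tert-butyl in place of methyl gives an at least 25-fold lower number from compound 2 to compound 3 (1.39 log units; beyond the scatter). That step is a bound rather than a measured size: the limit of > 62500 nM in this assay, at which 1 of the 3 values shown sits. On the amide-type nitrogen, 1-(tert-butoxycarbonyl)ethyl in place of 1-phenylethyl gives a 2.4-fold lower number from compound 1 to compound 3 (0.37 log units; beyond the scatter), so a group with no ring can serve there.

Where ethyl or isopropyl esters would fall relative to the methyl and tert-butyl esters remains open. Also open, on these data alone, is whether a free carboxylic acid or a tert-butyl amide in place of the ester would retain the activity of compound 3.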